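A Carbamate in Place of an Aryl Group: Expected Cytotoxicity

The source may report more compounds than this note shows. Statements on the series, on what has been measured and on what is new or still open speak of the compounds shown alone.

Compound 1, `COc1ccccc1N1CCN(C(=S)SCC(O)Cn2c([N+](=O)[O-])cnc2C)CC1`: > 5000000 nM
Compound 2, `CCN(C)C(=S)SCC(O)Cn1c([N+](=O)[O-])cnc1C`: 4150000 nM

Of the compounds shown here, two sharing one core have been tested in a toxicity assay on HeLa cells (Homo sapiens) for cytotoxicity, read by MTT assay, with a stated time of 24 h; a higher number here means a weaker inhibitor, a lower number a stronger inhibitor. For compound 1 the result is a limit of the assay, > 5000000 nM, and the limit of > 5000000 nM in this assay, at which 1 of the 2 values shown sits, shows that one of the two values sits there. Compound 2 gives 4150000 nM in this assay. With only a limit for compound 1, its standing among the numbers shown goes no further than that it lies at that limit. Among the measured compounds shown here, no step between measured compounds that differ in one place is available.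

Compound 3, `Cc1ncc([N+](=O)[O-])n1CC(O)CSC(=S)N1CCN(C(=O)OC(C)(C)C)CC1`, differs from compound 1 in one place: tert-butoxycarbonyl in place of 2-methoxyphenyl on an amine nitrogen in a ring. The change puts a tert-butoxycarbonyl where compound 1 carries a 2-methoxyphenyl, on an amine nitrogen in a ring. Because compound 1 reaches only a limit, > 5000000 nM, any step in this assay is expected to be small and probably none beyond the scatter, with the result again likely to sit at the limit. Compound 3 is expected to give about 5000000 nM, between 2500000 nM and 10000000 nM. That estimate is expected to mean a step of a number no higher from compound 1 to compound 3 (the limit leaves the size open).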

Compound 3, half-maximal inhibitory concentration: 689000 nM
Beside the measured number, compound 3's estimate is 7.3-fold (0.86 log units) above it; measured number outside the range, below it.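

In this assay, the group on this amine nitrogen in a ring does matter: tert-butoxycarbonyl in place of 2-methoxyphenyl gives an at least 7.2-fold lower number from compound 1 to compound 3 (0.86 log units; beyond the scatter). Compound 1 stands at a limit of the assay and not at a number, so the step has a lower bound but no known full size: the limit of > 5000000 nM in this assay, at which 1 of the 3 values shown sits. Among the compounds shown here, this pair is the first to show a single change moving the reading, and that change removes a six-membered aromatic ring of carbon only and brings in a group with no ring and a double bond outside aromatic rings.

The compounds shown do not separate the loss of the 2-methoxyphenyl ring from the arrival of the tert-butoxycarbonyl group, and they give no reason for the step. From the compounds shown here alone, it remains open how this assay would read with an acetyl group, a benzyl group or the free amine on that same nitrogen, and whether a phenyl ring without the methoxy group would stay at the limit seen for compound 1.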